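Restoring Potency After a Fluoro Substituent

The compounds below may be only part of what the source reports. "The series", "measured", "known", "first", "only" and "open" are said of these compounds alone.

Compound 2 `CCc1nc(NC(CC)CC)c(F)nc1-c1ccc(Cl)cc1Cl` gives 167 nM in an assay on IMR-32 cells for displacement of a labelled ligand from corticotropin-releasing factor receptor 1 (Homo sapiens), read by scintillation counting, with a stated time of 2 h (on this read-out lower numbers stand for stronger inhibition and higher numbers for weaker inhibition), and stands highest of the three numbers measured. Compound 1 `CCc1nc(-c2ccc(Cl)cc2Cl)c(CC)nc1NC(CC)CC` gives 4.1 nM, and compound 3 `CCC(CC)Nc1nc(OC)c(-c2ccc(Cl)cc2Cl)nc1OC` gives 8.4 nM. Compound 4 `CCOc1nc(-c2ccc(Cl)cc2Cl)c(CC)nc1NC(CC)CC` differs from compound 2 in one place: ethoxy in place of fluoro on an aromatic carbon. Among the measured compounds shown here, the single step that bears on this change is a 41-fold higher number from compound 1 to compound 2 (1.61 log units; beyond the scatter), a large loss when fluoro replaced ethyl. Compound 4 puts a larger group back there, and compound 3 shows that an alkoxy group at this place sits with a low number, so a large fall is expected, a 24-fold lower number from compound 2 to compound 4 (1.38 log units; beyond the scatter). Compound 4 is estimated at 7 nM, with a range of 2 nM to 25 nM.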

Compound 4, inhibition constant: 151 nM
Estimate against measurement, compound 4: 22-fold (1.33 log units) below; measured number above the stated range.
By their numbers in this assay, from the lowest: compound 1; then compound 3; then compounds 4 and 2 (each within the scatter of the next).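

In this assay, ethoxy in place of fluoro gives a 1.1-fold lower number from compound 2 to compound 4 (0.04 log units; within the scatter), so the larger group does not restore the low number at this position. Ethoxy in place of ethyl gives a 37-fold higher number from compound 1 to compound 4 (1.57 log units; beyond the scatter), which shows that the oxygen-linked ethoxy is not interchangeable with ethyl here, although both carry a two-carbon chain. Among compounds 1, 2 and 4, only ethyl gives a low number. Nothing available explains this difference. On these data alone, whether a propyl group or an amine at this position would match ethyl remains open.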